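A Methyl Group on the Core of Compound 2

The source may hold more compounds than are shown below. What is called first, only, known or untested is meant among the compounds shown, and "the series" means these compounds.

In a functional assay on HepG2 cells (Homo sapiens) for cytotoxicity, read by MTT assay, with a stated time of 72 h (on this read-out lower numbers stand for stronger inhibition and higher numbers for weaker inhibition), compound 1 `O=C(Nc1ccc(Oc2ccnc3[nH]ccc23)c(F)c1)c1nn(-c2ccccc2)ccc1=O` gives 24900 nM while compound 2 `O=C(Nc1ccc(Oc2ccnc3[nH]ccc23)c(F)c1)c1nn(-c2ccc(Br)cc2F)ccc1=O` gives 56500 nM as the higher of the two numbers. Among the measured compounds shown here, the one measured step of a 2.3-fold higher number from compound 1 to compound 2 (0.36 log units; beyond the scatter) is modest and comes from 4-bromo-2-fluorophenyl in place of phenyl on an aromatic nitrogen. Compound 3 `Cn1ccc2c(Oc3ccc(NC(=O)c4nn(-c5ccc(Br)cc5F)ccc4=O)cc3F)ccnc21` follows from compound 2 through methyl in place of hydrogen on an aromatic nitrogen and so puts methyl in place of hydrogen on an aromatic nitrogen. For the measured compounds named here, no measured step touches that place, so no step beyond the scatter is expected in this assay for this change. The expected step of a 1.3-fold lower number from compound 2 to compound 3 (0.10 log units; within the scatter) is therefore small. Compound 3 is estimated at 45000 nM with 18000 nM to 100000 nM as its expected range.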

Compound 3, half-maximal inhibitory concentration: 24000 nM
Compound 3: the middle estimate sits 1.9-fold (0.27 log units) above what was measured; the measured number falls inside the stated range.
By their numbers in this assay, from the lowest: compounds 3 and 1 (each within the scatter of the next); then compound 2.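

In this assay, among the compounds shown here, methyl in place of hydrogen on an aromatic nitrogen of the five-membered aromatic ring gives a 2.4-fold lower number from compound 2 to compound 3 (0.37 log units; beyond the scatter) and so provides the first measured step at this place. It shows that adding this single carbon to that nitrogen is enough to move the number beyond the scatter, here toward stronger inhibition. No available evidence accounts for this step. From the compounds shown here alone, whether an ethyl group, a longer chain or a chain ending in an amine on this nitrogen would move the number further remains open, as does whether methyl gives a similar step with the unsubstituted phenyl of compound 1.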